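Chloro in place of methoxy: an expectation for compound 3

A few compounds are considered here, and "the series" means these few. Any claim that something is new, unique, unknown or untested is made for them only; others in the source may bear on it.

Compound 1 `Cc1cccc(CNC(=O)/C=C/c2ccc(O)c(O)c2)c1` gives 3000 nM
Compound 2 `COc1ccc(CNC(=O)/C=C/c2ccc(O)c(O)c2)cc1` gives 6200 nM

Both compounds were tested in a functional assay on B16 cells (Mus musculus) for inhibition; a lower number here means a stronger inhibitor, a higher number a weaker inhibitor. Compound 2 stands at the higher of the two numbers, and its gap to compound 1 lies beyond the usual scatter, so compound 2 is the weaker inhibitor of this pair.

The next compound is compound 3 `O=C(/C=C/c1ccc(O)c(O)c1)NCc1ccc(Cl)cc1`, which has chloro in place of methoxy on an aromatic carbon, para to a large group (chloro in place of methoxy on an aromatic carbon). Among the compounds with values here, no measured pair isolates this change, so there is no direct guide to its size. Within the data shown here, the only evidence is that compound 1 gives 3000 nM while compound 2 gives 6200 nM, which places the known numbers close together.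

A small move towards a lower number in this assay is therefore expected, one not clearly beyond the scatter. The expected change a 1.6-fold lower number from compound 2 to compound 3 (0.19 log units; within the scatter) is an estimate that carries wide uncertainty. For compound 3 the estimated value is 4000 nM with an expected range from 1500 nM to 10000 nM as the likely span.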

Compound 3, half-maximal inhibitory concentration: 1800 nM
Compound 3: the middle estimate sits 2.2-fold (0.35 log units) above what was measured, within the range that was stated.
By their numbers in this assay, from the lowest: compounds 3 and 1 (each within the scatter of the next); then compound 2.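

In this assay, within the data shown here, replacing methoxy with chloro on an aromatic carbon, para to a large group, gives the first reading of a single change at this position: a 3.4-fold lower number from compound 2 to compound 3 (0.54 log units; beyond the scatter), a step beyond the scatter that shows this position is sensitive to the group it carries. The comparison with the 3-methylphenyl compound adds a second reading, a 1.7-fold lower number from compound 1 to compound 3 (0.22 log units; within the scatter), and as this lies within the scatter, the 4-chlorophenyl and 3-methylphenyl groups cannot be told apart in this assay. The compounds shown offer no evidence on why chloro and methoxy differ at this position.

Going by these compounds, with only chloro and methoxy compared at this position, it remains open whether bromo, an amine or a carboxylic acid in the same place would follow chloro, follow methoxy or fall elsewhere. The step from compound 1 to compound 3 also changes both the substituent and where it sits on the ring, so it cannot show how each of those two differences contributes on its own.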